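Chloro on the pendant phenyl in two pyrazole series

This account rests on a few compounds, and the source may have more. Where it says the series, first, only, none or still open, it means among the compounds named here.

Measured so far:
compound 1, `O=C(O)CCC(=O)/C=C/c1cn(-c2ccccc2)nc1-c1ccccc1`: 23.5%
compound 2, `O=C(O)CCC(=O)/C=C/c1cn(-c2ccccc2)nc1-c1ccc(Cl)cc1`: 8.64%
compound 3, `NC(=O)c1ccccc1NC(=O)c1cn(-c2ccccc2)nc1-c1ccccc1`: 9.88%

Working notes. In a functional assay on the whole organism (strain albino) for inhibition, with Rattus norvegicus as the target, read by paw edema, with stated times of 30 min and 4 h, at a dose of 50 mg/kg by the oral route (on this read-out lower numbers stand for less inhibition and higher numbers for more inhibition at the one dose given (going by the name of the read-out)), compound 1 gives 23.5%, compound 2 gives 8.64% and compound 3 gives 9.88%. Compound 3 thus stands second of the three numbers; its value lies within the scatter of compound 2 and beyond the scatter below compound 1.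

Compound 4, `NC(=O)c1ccccc1NC(=O)c1cn(-c2ccccc2)nc1-c1ccc(Cl)cc1`, is not yet measured in this assay. It differs from compound 3 by chloro in place of hydrogen on an aromatic carbon. Among the measured compounds shown here, the only measured step that bears on this change is a number 14.9 percentage points lower from compound 1 to compound 2 (beyond the scatter), the same exchange of chloro for hydrogen made on a different amide core. Carried over to compound 3, a drop of that size would run into the floor of the read-out, so compound 4 is expected to show at most a small number, with the change a number 6.9 percentage points lower from compound 3 to compound 4 (within the scatter) expected to be modest and downward or lost in the scatter. Compound 4 is estimated at 3%, within 0% to 14%.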

Compound 4, a percentage reported as inhibition, in the whole organism at one dose (the size of the read-out at that dose, not a potency): 9.26%
Estimate against measurement, compound 4: 6.3 percentage points below; the measured number falls inside the stated range.
By their numbers in this assay, from the lowest: compounds 2, 4 and 3 (each within the scatter of the next); then compound 1.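

In this assay, the phenyl to 4-chlorophenyl exchange, with chloro para to a large group, now has a second reading on a different core: a number 0.6 percentage points lower from compound 3 to compound 4 (within the scatter). What this change does at this position is therefore not constant and depends on the core that carries it, at least across these two pairs: the same change on two cores in this assay, a number 14.9 percentage points lower (beyond the scatter) from compound 1 to compound 2 and a number 0.6 percentage points lower (within the scatter) from compound 3 to compound 4, 14.2 percentage points apart, beyond the scatter of two such steps The loss seen in going to compound 2 thus cannot be taken as a general penalty for chloro at this position, since it does not carry over to compound 4.

Two pairs cannot show which part of the core of compound 1 sets this contrast. Going by these compounds, it also remains open whether a fluoro or methoxy group at this same position would follow chloro on each core.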